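This account rests on a few compounds, and the source may have more. Where it says the series, first, only, none or still open, it means among the compounds named here.

The series shares one core, carried by compound 1 `C=CCOc1cc(OC)c(C(=O)/C=C/C=C/c2ccccc2)c(OCC=C)c1`, compound 2 `C=CCOc1cc(OC)c(C(=O)/C=C/c2cccc(OC)c2)c(OCC=C)c1`, compound 3 `C=CCOc1cc(OC)c(C(=O)/C=C/c2ccccc2Br)c(OCC=C)c1` and compound 4 `C=CCOc1cc(OC)c(C(=O)/C=C/c2ccc(C)cc2)c(OCC=C)c1`; the four differ only in the group set on a double-bonded chain carbon bound to a double-bonded chain carbon. In an ADME assay on Vero cells (Chlorocebus sabaeus) for cytotoxicity, read by MTT assay (on this read-out lower numbers stand for stronger inhibition and higher numbers for weaker inhibition), compound 1 stands without a number, its entry reading "not determined" (no result reported), so it can be placed on this scale only through its neighbours. In this assay, going by the values given here, compound 2 gives 142000 nM and compound 3 gives 13900 nM; the one measured step between them, a 10-fold lower number from compound 2 to compound 3 (1.01 log units; beyond the scatter), shows that a change at this position can shift the read-out substantially.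

The step from compound 1 to compound 4 is a different exchange: 4-methylphenyl in place of 2-phenylethenyl on a double-bonded chain carbon bound to a double-bonded chain carbon. Among the compounds with values here, no measured step matches it, and compound 1 itself has no value, so the expectation for compound 4 rests on the two measured compounds alone. Compound 4 is closer in kind to compound 2 than to compound 3, and the measured step bears on it only as a sign of the spread this position allows. Compound 4 is therefore expected to fall near the weaker side of the range, at an estimated 90000 nM, with a plausible span from 20000 nM to 300000 nM.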

Compound 4, half-maximal inhibitory concentration: 211000 nM
Compound 4: middle estimate off by 2.3-fold (0.37 log units), on the low side; the range from low to high includes it.
By their numbers in this assay, from the lowest: compound 3; then compounds 2 and 4 (each within the scatter of the next).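

In this assay, the exchange at this position gives a 15-fold higher number from compound 3 to compound 4 (1.18 log units; beyond the scatter), while the exchange that brings in the same 4-methylphenyl group gives a 1.5-fold higher number from compound 2 to compound 4 (0.17 log units; within the scatter), which lies within the scatter. The low number of compound 3 is therefore no longer a contrast with a single partner: 3-methoxyphenyl and 4-methylphenyl cannot be told apart on this read-out, and among the three compounds with numbers only 2-bromophenyl stands apart. Nothing in the available data accounts for this separation.

Going by these compounds, the step from compound 1 to compound 4 cannot be read, since compound 1 has no number, so the effect of 2-phenylethenyl at this position remains unknown. Going by these compounds alone, with only one bromine-bearing compound in hand, it also remains open whether the separation belongs to the bromine itself or to where it sits on the ring, and how 4-bromophenyl, or a phenyl ring carrying an amine or a carboxylic acid, would fall on this scale.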